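Fluoro to Methoxy on a Second Core: Expected Weakening

This account rests on a few compounds, and the source may have more. Where it says the series, first, only, none or still open, it means among the compounds named here.

Measured compounds in a functional assay on PC-3 cells (Homo sapiens) for cytotoxicity, read by MTT assay, with a stated time of 48 h; on this read-out higher numbers stand for weaker inhibition and lower numbers for stronger inhibition:
Compound 1, `Cc1ccc(Cn2c(/C=C3\SC(=S)N(CC(=O)O)C3=O)nc3ccc(F)cc32)cc1`, gives 5820 nM.
Compound 2, `COc1ccc2nc(/C=C3\SC(=S)N(CC(=O)O)C3=O)n(Cc3ccc(C)cc3)c2c1`, gives 16200 nM.
Compound 3, `O=C(O)CN1C(=O)/C(=C/c2nc3ccc(F)cc3n2Cc2ccccc2F)SC1=S`, reaches only a limit of the assay, > 50000 nM.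

Compounds 1 and 2 share a core and differ by methoxy in place of fluoro on an aromatic carbon; this change gave a 2.8-fold higher number from compound 1 to compound 2 (0.44 log units; beyond the scatter). Compound 3 differs from compound 1 by 2-fluorophenyl in place of 4-methylphenyl on a saturated chain carbon bound to an aromatic nitrogen, and that change gave an at least 8.5-fold higher number from compound 1 to compound 3 (0.93 log units; beyond the scatter). Compound 3 therefore stands at the limit of > 50000 nM in this assay, at which 1 of the 3 values shown sits.

Compound 4, `COc1ccc2nc(/C=C3\SC(=S)N(CC(=O)O)C3=O)n(Cc3ccccc3F)c2c1`, is not yet measured in this assay. It differs from compound 3 by methoxy in place of fluoro on an aromatic carbon, the same change already seen between compounds 1 and 2, here made on the core of compound 3. Because the earlier instance of this change gave a 2.8-fold higher number from compound 1 to compound 2 (0.44 log units; beyond the scatter), compound 4 is expected to show a step that the limit leaves unreadable from compound 3 to compound 4. Compound 4 is thus estimated at about 120000 nM, spanning 40000 nM to 400000 nM, and will most likely again register only as a limit of this assay.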

Compound 4, half-maximal inhibitory concentration: > 50000 nM
Compound 4 ended at the assay's limit; the forecaster's own chance of this, stated with the estimate: 85%; the middle value is on the limit's open side.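

Compound 3 and compound 4 both reach only a limit in this assay, so the step of methoxy in place of fluoro cannot be read on this core, and it remains unknown whether the change seen on the core of compound 1 carries over: the limit of > 50000 nM in this assay, at which 2 of the 4 values shown sit.

The other change, 2-fluorophenyl in place of 4-methylphenyl, can be read on the methoxy core, where it gives an at least 3.0-fold higher number from compound 2 to compound 4 (0.48 log units; beyond the scatter). It points the same way on both cores, but whether its size is the same remains unknown: the same change on two cores in this assay, an at least 8.5-fold higher number (0.93 log units; beyond the scatter) from compound 1 to compound 3 and an at least 3.0-fold higher number (0.48 log units; beyond the scatter) from compound 2 to compound 4; the limit leaves it open whether they differ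

The compounds shown leave open how an amine in place of the fluoro or methoxy would behave. They also leave open whether any such group, paired with 2-fluorophenyl, would give a readable value.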